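The source may hold more compounds than are shown below. What is called first, only, known or untested is meant among the compounds shown, and "the series" means these compounds.

- Compound 1 `COCc1ccc(C(=O)NCc2ccc3cc(C(=O)NO)sc3c2F)o1`: 310 nM
- Compound 2 `O=C(NCc1ccc2cc(C(=O)NO)sc2c1F)c1ccco1`: 90 nM
- Compound 3 `O=C(NCc1ccc2cc(C(=O)NO)sc2c1F)c1ccc[nH]1`: 300 nM

In a functional assay on HCT-116 cells (Homo sapiens) for antiproliferative activity, read by resazurin assay, with a stated time of 5 days (on this read-out lower numbers stand for stronger inhibition and higher numbers for weaker inhibition), compound 2 stands lowest of the three at 90 nM, and its steps to both others lie beyond the scatter. Compound 4 `COc1ccccc1C(=O)NCc1ccc2cc(C(=O)NO)sc2c1F` has not yet been measured. It carries 2-methoxyphenyl in place of furan-2-yl on a carbonyl carbon.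

Going by the values given here, two measured steps bear on this change. The swap at the same place, with 1H-pyrrol-2-yl in place of furan-2-yl, gave a 3.3-fold higher number from compound 2 to compound 3 (0.52 log units; beyond the scatter). The other, with hydrogen in place of methoxymethyl on an aromatic carbon, gave a 3.4-fold lower number from compound 1 to compound 2 (0.54 log units; beyond the scatter). Among the compounds with values here, both are modest, and no measured compound carries a six-membered aromatic ring at this place, so the size remains uncertain. A modest rise beyond the scatter is nevertheless expected in this assay, rather than a fall. The expected change is a 3.0-fold higher number from compound 2 to compound 4 (0.48 log units; beyond the scatter). For compound 4 the estimated value is 270 nM, with an expected range from 90 nM to 800 nM.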

Compound 4, half-maximal inhibitory concentration: 1200 nM
The estimate for compound 4 lay 4.4-fold (0.65 log units) below the measured number; the whole stated range lies below it.
By their numbers in this assay, from the lowest: compound 2; then compounds 3 and 1 (each within the scatter of the next); then compound 4.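

In this assay, going by these compounds alone, the place on the carbonyl carbon proved far less tolerant than the earlier compounds had suggested: 2-methoxyphenyl in place of furan-2-yl brought a 13-fold higher number from compound 2 to compound 4 (1.12 log units; beyond the scatter) as a large step, where the earlier steps were modest. The weak end of the series also moved, with a 4.0-fold higher number from compound 3 to compound 4 (0.60 log units; beyond the scatter) and a 3.9-fold higher number from compound 1 to compound 4 (0.59 log units; beyond the scatter) both beyond the scatter, so compound 4 is the weakest of the four and neither 1H-pyrrol-2-yl nor 5-(methoxymethyl)furan-2-yl costs as much as this six-membered aromatic ring. No measurement on hand accounts for the size of this loss.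

The compounds shown do not separate the effect of the phenyl ring from that of its methoxy group, so an unsubstituted phenyl remains an open case. As far as these compounds go, how a pyridine ring, or a phenyl ring carrying an amine or a carboxylic acid, would read in this assay also stays open.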